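Compound 2 and the step to compound 4

The source may report more compounds than this note shows. Statements on the series, on what has been measured and on what is new or still open speak of the compounds shown alone.

Compound 1 (`Cc1ccc(NC(=O)Nc2cc(C)nc3ccccc23)cc1`): > 25000 nM
Compound 2 (`Cc1cc(NC(=O)Nc2cccc(F)c2)c2ccccc2n1`): > 25000 nM
Compound 3 (`Cc1cc(NC(=O)Nc2cccc(C(F)(F)F)c2)c2ccccc2n1`): 16000 nM

In an ADME assay on HEK293 cells (Homo sapiens) for cytotoxicity, with a stated time of 72 h (on this read-out higher numbers stand for an effect only at larger amounts of compound and lower numbers for an effect already at smaller amounts), compound 2 stands at > 25000 nM as a limit of the assay and not a number. Compound 1 is also reported only as a limit, and the limit of > 25000 nM in this assay, at which 2 of the 3 values shown sit, is what the two have in common. Compound 4 (`Cc1cc(NC(=O)Nc2ncccc2C)c2ccccc2n1`) is not yet measured. On an amide-type nitrogen it carries 3-methylpyridin-2-yl in place of 3-fluorophenyl on an amide-type nitrogen (the full change). For the measured compounds named here, two measured steps bear on this. At that same nitrogen, a step that the two limits leave unreadable from compound 1 to compound 2 gives no size to work from. Going by the values given here, on an aromatic carbon, the other change gives an at least 1.5-fold lower number from compound 2 to compound 3 (0.19 log units; that floor lies within the scatter) as the only readable step. No step beyond the scatter is therefore expected in this assay and no direction can be read. The expected step is a step that the limit leaves unreadable from compound 2 to compound 4 in this estimate. Compound 4 is estimated at 28000 nM with 13000 nM to 55000 nM as its expected range.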

Compound 4, half-maximal effective concentration: > 25000 nM
Compound 4: only a limit was reported; the forecaster's own chance of this, stated with the estimate: 70%; the middle value is on the limit's open side.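

In this assay compound 4 gives > 25000 nM, a limit of the assay and not a number. Its steps from compound 1 and compound 2 cannot be read, because all three compounds share one limit: the limit of > 25000 nM in this assay, at which 3 of the 4 values shown sit.

The compounds shown leave open whether compound 1, compound 2 and compound 4 differ at all on this read-out.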